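Dimethylamino for imidazolyl: one change, two cores

The source may report more compounds than this note shows. Statements on the series, on what has been measured and on what is new or still open speak of the compounds shown alone.

Compound 1 `COC(=O)N(C)CC#CCn1ccnc1` anchors the series; in a functional assay on the whole organism for agonist activity, with Mus musculus as the target (a higher number here means that more compound is needed for the effect, a lower number that less compound is needed), compound 1 gives 2 mg/kg. Compound 2 `COC(=O)N(C)CC#CCN(C)C` differs from it by dimethylamino in place of 1H-imidazol-1-yl on a saturated chain carbon bound to a triple-bonded carbon, and in this assay compound 2 gives 17.3 mg/kg, so the step of an 8.7-fold higher number from compound 1 to compound 2 (0.94 log units; beyond the scatter) sets the scale for this change. Compound 3 `Cn1ccn(CC#CCn2ccnc2)c1=O` carries another core; the difference between the cores of compound 1 and compound 3 is not broken down here. In this assay compound 3 gives 4.5 mg/kg. Compound 4 `CN(C)CC#CCn1ccn(C)c1=O` is compound 3 with dimethylamino in place of 1H-imidazol-1-yl on a saturated chain carbon bound to a triple-bonded carbon, the same change as from compound 1 to compound 2. Among the compounds with values here, only that single measured instance is available, so no pattern beyond these compounds is claimed. Within the data shown here, compound 4 is expected to show a 7.8-fold higher number from compound 3 to compound 4 (0.89 log units; beyond the scatter) because the one precedent an 8.7-fold higher number from compound 1 to compound 2 (0.94 log units; beyond the scatter) is the sole guide. Compound 4 is estimated at 35 mg/kg, with a range from 12 mg/kg to 100 mg/kg.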

Compound 4, dose for half-maximal effect: 5.4 mg/kg
Beside the measured number, compound 4's estimate is 6.5-fold (0.81 log units) above it; measured number outside the range, below it.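

Notes on the change: in this assay, dimethylamino in place of 1H-imidazol-1-yl does not carry the same size of step from one core to the other: the same change on two cores in this assay, an 8.7-fold higher number (0.94 log units; beyond the scatter) from compound 1 to compound 2 and a 1.2-fold higher number (0.08 log units; within the scatter) from compound 3 to compound 4, 7.2-fold (0.86 log units) apart, beyond the scatter of two such steps.
On the core of compound 3, the step is a 1.2-fold higher number from compound 3 to compound 4 (0.08 log units; within the scatter) and thus gives no measurable shift, unlike the large step on the core of compound 1.
These two pairs show that the size of this step depends on the core in these compounds, but they do not show which part of the cores is responsible, and they support no rule for the wider series.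

Still open, as far as these compounds go, is whether diethylamino or a longer chain on the same carbon would follow the core of compound 1 or the core of compound 3. A third core would be needed to tell which of the two steps is the more typical.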